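The compounds below may be only part of what the source reports. "The series", "measured", "known", "first", "only" and "open" are said of these compounds alone.

In a functional assay (blood) for inhibition, with Homo sapiens as the target (a higher number here means a weaker inhibitor, a lower number a stronger inhibitor), three compounds sharing one core differ only in the group on one aromatic carbon. Compound 1 `COCc1cc(-c2ccccc2)c2ccc(OCc3cccc(C4(O)CCOCC4)c3)cc2c1` carries methoxymethyl there, and its reading of 200 nM serves as the starting point. Compound 3 `COC(=O)c1cc(-c2ccccc2)c2ccc(OCc3cccc(C4(O)CCOCC4)c3)cc2c1` carries methoxycarbonyl, and its reading of 100 nM stands level with that of compound 1 within the scatter. Compound 2 `COC(C)c1cc(-c2ccccc2)c2ccc(OCc3cccc(C4(O)CCOCC4)c3)cc2c1` carries 1-methoxyethyl, and its reading of > 1000 nM is only a limit.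

Compound 4 `N#Cc1cc(-c2ccccc2)c2ccc(OCc3cccc(C4(O)CCOCC4)c3)cc2c1` puts cyano in place of methoxycarbonyl on that aromatic carbon, a change counted as cyano in place of methoxycarbonyl on an aromatic carbon and not yet measured. Among the measured compounds shown here, three measured steps bear on it. The two large ones, an at least 5.0-fold higher number from compound 1 to compound 2 (0.69 log units; beyond the scatter) and an at least 10-fold lower number from compound 2 to compound 3 (1.00 log units; beyond the scatter), both involve compound 2, whose group plays no part in this change. For the measured compounds named here, because a 2.0-fold lower number from compound 1 to compound 3 (0.30 log units; within the scatter) is the only swap that leaves compound 2 out, a small step is expected. So the step expected in this assay is a 1.5-fold higher number from compound 3 to compound 4 (0.18 log units; within the scatter) with no shift beyond the scatter foreseen. For compound 4 the estimated value is 150 nM with 50 nM to 500 nM as its likely range.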

Compound 4, half-maximal inhibitory concentration: 100 nM
Compound 4: middle estimate off by 1.5-fold (0.18 log units), on the high side, and the stated range covers the measured number.
By their numbers in this assay, from the lowest: compounds 3, 4 and 1 (each within the scatter of the next). At a limit, above all of these: compound 2.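

In this assay, replacing methoxycarbonyl with cyano, a group with fewer heavy atoms, a triple bond in place of a double bond and no oxygen, gives no change at the digits printed from compound 3 to compound 4 (within the scatter). Measured against methoxymethyl, the change gives a 2.0-fold lower number from compound 1 to compound 4 (0.30 log units; within the scatter), so compound 1, compound 3 and compound 4 stand level at this position despite carrying three different groups. Compound 2 goes against this picture, with 1-methoxyethyl giving an at least 10-fold lower number from compound 2 to compound 4 (1.00 log units; beyond the scatter), a step read from the limit that compound 2 gives in this assay.

As far as these compounds go, whether an amine, a carboxylic acid or a longer chain such as ethoxymethyl on this aromatic carbon would stay level with compound 3 and compound 4 remains open. The readings also do not tell why compound 2 alone stands apart.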